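This account rests on a few compounds, and the source may have more. Where it says the series, first, only, none or still open, it means among the compounds named here.

Measured in a functional assay on A549 cells (Homo sapiens) for cytotoxicity, read by MTT assay, with a stated time of 48 h; a lower number here means a stronger inhibitor, a higher number a weaker inhibitor:
compound 1 `COc1cc(-c2nnc3n2NC(c2ccco2)C(C(=O)c2ccccc2C)S3)cc(OC)c1OC`: 80000 nM
compound 2 `COc1cc(-c2nnc3n2NC(c2ccco2)C(C(=O)c2ccccc2)S3)cc(OC)c1OC`: 33400 nM

Among the measured compounds shown here, compound 2 stands at the lower of the two numbers; the one measured step is a 2.4-fold lower number from compound 1 to compound 2 (0.38 log units; beyond the scatter), a modest change. Compound 3 `COc1cc(-c2nnc3n2NC(c2ccco2)C(C(=O)c2ccc(F)c(F)c2)S3)cc(OC)c1OC` differs from compound 2 by 3,4-difluorophenyl in place of phenyl on a carbonyl carbon. For the measured compounds named here, no measured step covers fluorine on the benzoyl ring; the only step available concerns a methyl there and was modest, so the expected step of a 1.1-fold lower number from compound 2 to compound 3 (0.05 log units; within the scatter) is estimated not to go beyond the scatter, in either direction. For compound 3 the estimate in this assay is 30000 nM, with a range of 10000 nM to 90000 nM.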

Compound 3, half-maximal inhibitory concentration: 93700 nM
Beside the measured number, compound 3's estimate is 3.1-fold (0.49 log units) below it, outside the stated range (above it).
By their numbers in this assay, from the lowest: compound 2; then compounds 1 and 3 (each within the scatter of the next).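

In this assay, the change to 3,4-difluorophenyl on the carbonyl carbon gives (a 2.8-fold higher number from compound 2 to compound 3 (0.45 log units; beyond the scatter)), so fluorine, like methyl, moves the number upward from the unsubstituted phenyl of compound 2. Compound 1 and compound 3 do not separate (a 1.2-fold higher number from compound 1 to compound 3 (0.07 log units; within the scatter)), and of the three rings shown, only the unsubstituted phenyl stands apart. No available evidence bears on the reason for this step. From the compounds shown here alone, it remains open whether an amine or a carboxylic acid on the benzoyl ring would stay with compound 2 or with the two substituted compounds.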